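Alkoxy chain length at the pyrimidine ether in a CXCR3 series

The source may hold more compounds than are shown below. What is called first, only, known or untested is meant among the compounds shown, and "the series" means these compounds.

Measured compounds:
compound 1, `CCOc1ncc(-c2nc(C(F)(F)F)sc2N2CCN(C(=O)Cn3nc(C)nc3C)[C@H](C)C2)cn1`, 173 nM
compound 2, `COc1ncc(-c2nc(C(F)(F)F)sc2N2CCN(C(=O)Cn3nc(C)nc3C)[C@H](C)C2)cn1`, 558 nM

Compound 2 stands highest of the two numbers in a functional assay on U2OS cells for antagonist activity at C-X-C chemokine receptor type 3 (Homo sapiens), read by beta-arrestin recruitment; a higher number here means a weaker inhibitor, a lower number a stronger inhibitor. Going by the values given here, its nearest neighbour is compound 1, and the only step available, a 3.2-fold higher number from compound 1 to compound 2 (0.51 log units; beyond the scatter), arises from hydrogen in place of methyl on a saturated chain carbon bound to an oxygen on an aromatic ring.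

Compound 3, `Cc1nc(C)n(CC(=O)N2CCN(c3sc(C(F)(F)F)nc3-c3cnc(OC(C)C)nc3)C[C@H]2C)n1`, has not yet been measured. It differs from compound 2 as follows: isopropyl in place of methyl on an oxygen on an aromatic ring. Among the compounds with values here, the single measured step bears directly on this change, since it concerns the same oxygen on the same aromatic ring, but in the opposite sense: removing a carbon from the chain weakened inhibition modestly and beyond the scatter, whereas the move to compound 3 extends the group at that place. Whether extension beyond the ethyl of compound 1 continues the trend or levels off cannot be read from two compounds, so the estimate sits near the ethoxy value with a wide range.

Compound 3 is expected to give about 140 nM, between 45 nM and 450 nM. The step expected in this assay is a 4.0-fold lower number from compound 2 to compound 3 (0.60 log units; beyond the scatter).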

Compound 3, half-maximal inhibitory concentration: 138 nM
For compound 3 the middle estimate is 1.0-fold (0.01 log units) above the measured one; the measured number falls inside the stated range.
By their numbers in this assay, from the lowest: compounds 3 and 1 (each within the scatter of the next); then compound 2.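

In this assay, isopropyl in place of methyl on the oxygen on the aromatic ring gives a 4.0-fold lower number from compound 2 to compound 3 (0.61 log units; beyond the scatter) and so shows that a branched group at this place is accepted, which the linear pair could not show. Against the ethoxy compound, the same group gives a 1.3-fold lower number from compound 1 to compound 3 (0.10 log units; within the scatter) and this leaves ethoxy and isopropoxy indistinguishable, so the methyl added to the saturated chain carbon bound to the oxygen has no effect that can be resolved here. Across the three compounds, the clear separation therefore lies only between methoxy and the two larger alkoxy groups, and no compound goes against that reading.

On these data alone, whether this level holds for a longer chain such as n-butoxy, or for a cyclopropylmethoxy group, remains open, as does the response to an amine or a hydroxyl at the end of the chain. As far as these compounds go, it is also open whether the same ordering would persist with a different group in place of the dimethyltriazole acetamide, and no supporting data accompany these results to explain the separation.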